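The compounds below may be only part of what the source reports. "The series", "measured", "known", "first", "only" and "open" are said of these compounds alone.

Three compounds share one core, a five-membered aromatic ring with three nitrogens carrying a variable group on one of its nitrogens. Compound 1 `CC(C)=CCC1=C(OCc2cn(C3CCN(C(=O)OC(C)(C)C)CC3)nn2)C(=O)c2ccccc2C1=O` gives 136000 nM in an ADME assay on HepG2 cells (Homo sapiens) for cytotoxicity, read by MTT assay, with a stated time of 24 h; a higher number here means that more compound is tolerated, a lower number that less compound is tolerated. Compound 2 `CC(C)=CCC1=C(OCc2cn(Cc3ccccn3)nn2)C(=O)c2ccccc2C1=O` gives 658000 nM in this assay, and compound 3 `CC(C)=CCC1=C(OCc2cn(-c3cccc(F)c3)nn2)C(=O)c2ccccc2C1=O` gives 265000 nM. For the measured compounds named here, the only single-point step among the measured compounds is a 2.5-fold lower number from compound 2 to compound 3 (0.39 log units; beyond the scatter). On the numbers shown compound 3 sits between the other two, though its gap to compound 1 is within the scatter while its gap to compound 2 is beyond it.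

Compound 4 `COc1cc([N+](=O)[O-])ccc1-n1cc(COC2=C(CC=C(C)C)C(=O)c3ccccc3C2=O)nn1` differs from compound 3 by 2-methoxy-4-nitrophenyl in place of 3-fluorophenyl on an aromatic nitrogen. Going by the values given here, only the step from compound 2 to compound 3 touches the same aromatic nitrogen, and it exchanged an arylmethyl for an aryl rather than one aryl for another, so it bears on this change only loosely; its size was modest. Among the compounds with values here, no measured step shows how swapping one aryl for another on that nitrogen moves this assay. For compound 4 a step within the scatter, or at most a modest one in either direction, is expected, a 1.2-fold lower number from compound 3 to compound 4 (0.08 log units; within the scatter). Compound 4 is therefore estimated at 220000 nM, with a range from 80000 nM to 600000 nM.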

Compound 4, half-maximal cytotoxic concentration: 701000 nM
For compound 4 the middle estimate is 3.2-fold (0.50 log units) below the measured one; the measured number lies above the stated range.
By their numbers in this assay, from the lowest: compounds 1 and 3 (each within the scatter of the next); then compounds 2 and 4 (each within the scatter of the next).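

For the compounds shown here, exchanging one aryl group for another on this aromatic nitrogen, a change that no earlier step covered, gives a 2.6-fold higher number from compound 3 to compound 4 (0.42 log units; beyond the scatter) in this assay, so the number depends on which aryl group sits there and not only on whether an aryl or an arylmethyl group does. The 2-methoxy-4-nitrophenyl group also gives a 1.1-fold higher number from compound 2 to compound 4 (0.03 log units; within the scatter) against the (pyridin-2-yl)methyl group, a step within the scatter, so an aryl group directly on this nitrogen does not in itself go with a lower number. Nothing at hand explains why the two aryl groups differ.

Compound 4 brings its methoxy and nitro groups together, so the shares of each in the step cannot be separated. On these data alone, how an amine or a carboxylic acid on this aryl ring would move the number remains open.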